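Dithiocarbamate disulfides: cytotoxicity in HeLa cells

The source may report more compounds than this note shows. Statements on the series, on what has been measured and on what is new or still open speak of the compounds shown alone.

Measured so far:
compound 1 `CCN(C)C(=S)SC(=S)N(C)C`: 2070000 nM
compound 2 `CCOC(=O)N1CCN(C(=S)SC(=S)N(C)C)CC1`: 530000 nM

In an ADME assay on HeLa cells (Homo sapiens) for cytotoxicity, read by MTT assay, with a stated time of 24 h (a higher number here means a weaker inhibitor, a lower number a stronger inhibitor), compound 1 gives 2070000 nM, while compound 2 gives 530000 nM. Compound 2 therefore stands at the lower of the two numbers, with compound 1 beyond the scatter above it.

Compound 3 `CCSC(=S)N1CCN(C(=S)SC(=S)N(C)C)CC1` differs from compound 2 in one place: a group of 5 heavy atoms (3 carbon, 2 sulfur; no ring) in place of a group of 5 heavy atoms (3 carbon, 2 oxygen; no ring), on an amine nitrogen in a ring. Among the measured compounds shown here, no measured pair of this kind exists in the set, so the size of the step rests on judgment alone. A small step toward a lower number is expected in this assay, close to the scatter. The expected step is a 1.5-fold lower number from compound 2 to compound 3 (0.18 log units; within the scatter). Compound 3 is estimated at 350000 nM, with a range from 100000 nM to 1200000 nM.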

Compound 3, half-maximal inhibitory concentration: 4480000 nM
For compound 3 the middle estimate is 13-fold (1.11 log units) below the measured one; measured number above the stated range.
By their numbers in this assay, from the lowest: compound 2; then compound 1; then compound 3.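

In this assay, replacing the ethoxycarbonyl on the amine nitrogen in the ring with the group carrying 2 sulfur in place of 2 oxygen gives an 8.5-fold higher number from compound 2 to compound 3 (0.93 log units; beyond the scatter). This position therefore responds to an exchange that leaves the heavy-atom count, double bonds and hydrogen-bond counts of the group unchanged. No measurement at hand accounts for the size or direction of this step.

Open, going by these compounds, is whether a group with one sulfur and one oxygen gives an intermediate number. Also open, on these data alone, is how an acetyl or a benzyl group on the same nitrogen would compare.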